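The compounds below may be only part of what the source reports. "The series", "measured", "known", "first", "only" and "open" are said of these compounds alone.

Two semicarbazone derivatives of the same core have been taken through a functional assay on the whole organism (strain Swiss albino) with Mus musculus as the target, with a stated time of 4 h (a lower number here means that less compound is needed, a higher number that more compound is needed for the effect), so far. Compound 1 `C=C(C)[C@@H]1CC=C(C)/C(=N/NC(=O)Nc2nnc(-c3ccc(F)cc3)o2)C1` carries a cyclic terpene-derived chain on the hydrazone side; in this assay compound 1 gives 300 mg/kg. Compound 2 `CC(C)=CC/C=C(/C)C/C=N/NC(=O)Nc1nnc(-c2ccc(F)cc2)o1` carries an open-chain analogue of that side chain on the same core; in this assay compound 2 gives 300 mg/kg. On these two numbers compound 2 stands level with compound 1 at the digits shown, its nearest neighbour in the set, and no change beyond the scatter is seen between them. Among the compounds with values here, no single-point step between measured compounds exists, so the dependence of the minimum effective dose on the aryl substituent is unknown.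

The next compound, compound 3 `CC(C)=CC/C=C(/C)C/C=N/NC(=O)Nc1nnc(-c2ccc(O)cc2)o1`, keeps the open-chain side of compound 2 and changes only the aryl group: hydroxy in place of fluoro on an aromatic carbon. With two measured compounds reading the same, no direction is evident, and the step is expected to stay within the scatter: no change at the digits printed from compound 2 to compound 3 (within the scatter). For compound 3 the minimum effective dose in this assay is estimated at 300 mg/kg, in the range 150 mg/kg to 600 mg/kg.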

Compound 3, minimum effective dose: 300 mg/kg
Compound 3: middle estimate and measured number agree at the digits printed; the range from low to high includes it.
By their numbers in this assay, from the lowest: compounds 1, 2 and 3 (each within the scatter of the next).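

Hydroxy in place of fluoro on an aromatic carbon, para to a large group, gives no change at the digits printed from compound 2 to compound 3 (within the scatter) in this assay and this is the first reading of the aryl position with the open-chain side held constant. Going from 4-fluorophenyl to 4-hydroxyphenyl brings in a hydrogen-bond donor and a hydrogen-bond acceptor where fluoro has neither, yet the minimum effective dose does not separate the two compounds, so on this one pair the position accepts either group in this read-out. Nothing measured alongside these numbers offers a reason for the match between the two groups.

Still open, from the compounds shown here alone, is whether the same position keeps this reading with an amine, a carboxylic acid or a longer chain such as butoxy in place of hydroxy, and whether hydroxy reads the same when paired with the cyclic terpene-derived side of compound 1. Going by these compounds, with all three compounds on one printed number, it also remains open whether any aryl group at this position can move the minimum effective dose away from that level.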